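Moving the fluorine on the carbonyl-bound phenyl ring

The compounds below may be only part of what the source reports. "The series", "measured", "known", "first", "only" and "open" are said of these compounds alone.

Measured so far:
compound 1 `O=C(NCc1ccc(CNS(=O)(=O)c2ccccc2)cc1)c1cccc(F)c1`: 100 nM
compound 2 `Cc1ccc(S(=O)(=O)NCc2ccc(CNC(=O)c3ccccc3)cc2)cc1`: a limit, > 1000 nM
compound 3 `COc1cccc(C(=O)NCc2ccc(CNS(=O)(=O)c3ccc(C)cc3)cc2)c1`: 10 nM

In an assay on MDA-MB-231 cells for binding affinity to C-X-C chemokine receptor type 4 (Homo sapiens), read by immunofluorescence and microscopy, with stated times of 10 min and 30 min (on this read-out lower numbers stand for an effect already at smaller amounts and higher numbers for an effect only at larger amounts of compound), compound 1 gives 100 nM, the highest of the two numbers shown. Compound 3 gives 10 nM in this assay. Compound 2 reaches only a limit of the assay, > 1000 nM, as summarised in the limit of > 1000 nM in this assay, at which 1 of the 3 values shown sits. Among the compounds with values here, the one measured step, an at least 100-fold lower number from compound 2 to compound 3 (2.00 log units; beyond the scatter), concerns a methoxy in place of hydrogen on an aromatic carbon. Compound 4 `O=C(NCc1ccc(CNS(=O)(=O)c2ccccc2)cc1)c1ccccc1F` differs from compound 1 by 2-fluorophenyl in place of 3-fluorophenyl on a carbonyl carbon. Within the data shown here, no measured step tests moving a fluorine on this ring, so nothing here points to a change beyond the scatter. Compound 4 is therefore expected near compound 1, at 150 nM, between 40 nM and 600 nM, a step of a 1.5-fold higher number from compound 1 to compound 4 (0.18 log units; within the scatter).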

Compound 4, effective concentration (reported as EC, without a stated level of effect): 1000 nM
For compound 4 the middle estimate is 6.7-fold (0.82 log units) below the measured one; the measured number lies above the stated range.
By their numbers in this assay, from the lowest: compound 3; then compound 1; then compound 4.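

Where the fluorine sits on this ring matters: the atoms stay the same, yet 2-fluorophenyl in place of 3-fluorophenyl on the carbonyl carbon gives a 10-fold higher number from compound 1 to compound 4 (1.00 log units; beyond the scatter). Within the data shown here, the earlier compounds showed only that adding a group to this ring can change the number, not that moving one can. Nothing measured here explains the change.

Still open, going by these compounds, is whether another group in place of that fluorine, such as an amine or a carboxylic acid, would give a lower number than fluorine does.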